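The compounds below may be only part of what the source reports. "The series", "measured", "known", "first", "only" and "open" are said of these compounds alone.

Compound 1 `Cc1cc(/C=C/C#N)cc(C)c1Oc1ccc([N+](=O)[O-])c(Nc2ccc(C#N)cc2)n1` and compound 3 `Cc1cc(/C=C/C#N)cc(C)c1Oc1ccc(N)c(Nc2ccc(C#N)cc2)n1` share one core, and compound 3 carries amino in place of nitro on an aromatic carbon. In an ADME assay on TZM cells (Homo sapiens) for cytotoxicity, read by XTT assay, with a stated time of 4 days (on this read-out lower numbers stand for higher toxicity in this test and higher numbers for lower toxicity in this test), compound 1 gives > 48600 nM, which is a limit of the test rather than a number. In this assay compound 3 gives 9750 nM. That change gave an at least 4.9-fold lower number from compound 1 to compound 3 (0.69 log units; beyond the scatter). Compound 2 `Cc1cc(/C=C/C#N)cc(C)c1Oc1ccc([N+](=O)[O-])c(Nc2ccc(C#N)cc2)c1` rests on a different core; the difference between the two cores is not broken down here. In this assay compound 2 gives > 48700 nM, again only a limit. Compound 4 `Cc1cc(/C=C/C#N)cc(C)c1Oc1ccc(N)c(Nc2ccc(C#N)cc2)c1` carries the same kind of change, (amino in place of nitro on an aromatic carbon), here on a six-membered aromatic ring of carbon only rather than on a six-membered aromatic ring with 1 nitrogen, two atoms from the ring nitrogen. Expected here is an at least 4.8-fold lower number from compound 2 to compound 4 (0.68 log units; beyond the scatter), which rests on an at least 4.9-fold lower number from compound 1 to compound 3 (0.69 log units; beyond the scatter). Compound 4 is therefore estimated at 10000 nM, between 4000 nM and 48700 nM.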

Compound 4, half-maximal cytotoxic concentration: 25000 nM
Beside the measured number, compound 4's estimate is 2.5-fold (0.40 log units) below it; low and high end bracket the measured number.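

Carried to the second core, the change from nitro to amino gave an at least 1.9-fold lower number from compound 2 to compound 4 (0.28 log units; that floor lies within the scatter) in this assay. Set beside the earlier step, this does not show whether the change acts to the same extent on both cores: the same change on two cores in this assay, an at least 4.9-fold lower number (0.69 log units; beyond the scatter) from compound 1 to compound 3 and an at least 1.9-fold lower number (0.28 log units; that floor lies within the scatter) from compound 2 to compound 4; the limit leaves it open whether they differ. The nitro compound on this core offers only a limit as its starting point: the limit of > 48700 nM in this assay, at which 1 of the 4 values shown sits.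

The compounds shown leave open how other groups in the same place, such as a hydroxyl, a methylamino or an acetamido group, would read in this test. They also leave open whether the change would give a similar step on a third core.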